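Sulfonyl variation on an inactive quinolone scaffold

This account rests on a few compounds, and the source may have more. Where it says the series, first, only, none or still open, it means among the compounds named here.

The shared core of compound 1 `COc1ccc(-c2cc(=O)c3c(OC)cc(OC)cc3[nH]2)cc1` carries no substituent on the ring nitrogen, and in a functional assay on KOPN-8 cells (Homo sapiens) for antiproliferative activity, with a stated time of 72 h (on this read-out lower numbers stand for an effect already at smaller amounts and higher numbers for an effect only at larger amounts of compound), compound 1 gives > 31100 nM, a limit of the assay rather than a number. Compound 2 `COc1ccc(-c2cc(=O)c3c(OC)cc(OC)cc3n2S(=O)(=O)c2ccc(C)c([N+](=O)[O-])c2)cc1` adds a 4-methyl-3-nitrophenyl group on a sulfonyl sulfur attached to that nitrogen. In this assay compound 2 also reaches only a limit, > 51700 nM. Compound 3 `COc1ccc(-c2cc(=O)c3c(OC)cc(OC)cc3n2S(=O)(=O)c2cc(F)c(F)c(F)c2)cc1` replaces that group with a 3,4,5-trifluorophenyl ring. In this assay compound 3 again stands at a limit, > 65500 nM. The only measured step bearing on the new change is a step that the two limits leave unreadable from compound 2 to compound 3, so the three compounds shown give no readable number, only the limits (the limit of > 31100 nM in this assay, at which 1 of the 3 values shown sits), the limit of > 51700 nM in this assay, at which 1 of the 3 values shown sits, and (the limit of > 65500 nM in this assay, at which 1 of the 3 values shown sits).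

Compound 4 `COc1ccc(-c2cc(=O)c3c(OC)cc(OC)cc3n2S(=O)(=O)c2ccc(Cl)cc2)cc1` is related to compound 3 by 4-chlorophenyl in place of 3,4,5-trifluorophenyl on a sulfonyl sulfur. No measured step in this series has shown an effect within the range of the assay, so no direction can be read for this change. He therefore expects compound 4 to behave like the other sulfonyl compounds and to show no effect within the measured range, with the step of an at least 1.1-fold lower number from compound 3 to compound 4 (0.07 log units; that floor lies within the scatter) estimated as lying within the scatter. His estimate for compound 4 in this assay is 55000 nM, in the range 20000 nM to 150000 nM.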

Compound 4, half-maximal effective concentration: > 34400 nM
Compound 4: a limit, no number; the forecaster's own chance of this, stated with the estimate: 85%; the middle value does not contradict the limit.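

In this assay compound 4 gives > 34400 nM, a limit of the assay and not a number. None of the steps to compound 4 from compound 1, compound 2 or compound 3 can be read. The compounds shown leave open whether any group on the sulfonyl sulfur gives an effect within the measured range of this assay, and how such groups would rank.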